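The source may report more compounds than this note shows. Statements on the series, on what has been measured and on what is new or still open speak of the compounds shown alone.

Among the compounds with values here, compound 1 `CCNCc1cn(Cc2ccccc2)c2ccccc12` is the weaker of the two compounds measured so far. In an assay on isolated protein for inhibition of Amine oxidase [flavin-containing] B (Rattus norvegicus) (on this read-out higher numbers stand for weaker inhibition and lower numbers for stronger inhibition), compound 1 gives 429000 nM, the highest of the two numbers; compound 2 `C#CCN(C)Cc1cc2cc(O)ccc2n1C` gives 820 nM in this assay, a gap well beyond the usual scatter. The two differ in more than one place, so only their values can be set side by side, not a single step.

Compound 3 `C#CCN(C)Cc1cn(Cc2ccccc2)c2ccccc12` keeps the core of compound 1 and carries one change: methyl(propargyl)amino in place of ethylamino on a saturated chain carbon bound to an aromatic carbon. Compound 2 already carries methyl(propargyl)amino on its own, different core and stands far lower in this assay.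

On that basis, the step in this assay from compound 1 to compound 3 is expected to be large and downward, toward stronger inhibition, because compound 2 gives 820 nM with the same methyl(propargyl)amino group in place, though on another core, which leaves the size uncertain; the expected step is a 54-fold lower number from compound 1 to compound 3 (1.73 log units; beyond the scatter). Compound 3 is estimated to give 8000 nM in this assay, within a range from 1000 nM to 60000 nM.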

Compound 3, inhibition constant: 476000 nM
Compound 3: the middle estimate sits 60-fold (1.77 log units) below what was measured; measured number outside the range, above it.
By their numbers in this assay, from the lowest: compound 2; then compounds 1 and 3 (each within the scatter of the next).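

In this assay, exchanging ethylamino for methyl(propargyl)amino on a saturated chain carbon bound to an aromatic carbon, on the core of compound 1, gives a step of a 1.1-fold higher number from compound 1 to compound 3 (0.05 log units; within the scatter) and so leaves the read-out unmoved within the scatter. On this core, then, the change from the smaller ethylamino to the larger methyl(propargyl)amino, which also removes the hydrogen-bond donor and brings in a triple bond, is not visible in this read-out, and the number given by compound 2 cannot be credited to methyl(propargyl)amino alone, as that compound differs from compound 3 in more than one place. No independent measurement among the data offers an explanation for this flat step.

The compounds shown leave open whether a primary amine, dimethylamino or a longer chain such as propylamino at this same place would also leave the number where it stands on this core. They also leave open which of the differences between compound 2 and compound 3 matters, a question that a single change on the shared core, such as a methyl in place of the benzyl group, could begin to address.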